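A few compounds are considered here, and "the series" means these few. Any claim that something is new, unique, unknown or untested is made for them only; others in the source may bear on it.

Compound 1 `COc1ncc(-c2ccc3c(c2)N(C2CC2)C(=O)CO3)cc1NS(=O)(=O)c1ccc(F)cc1` and compound 3 `COc1ccc(N2C(=O)COc3ccc(-c4cnc(OC)c(NS(=O)(=O)c5ccc(F)cc5)c4)cc32)cc1` share one core and differ in a single place: 4-methoxyphenyl in place of cyclopropyl on an amide-type nitrogen in a ring. In a functional assay on HCT-116 cells (Homo sapiens) for antiproliferative activity, read by MTT assay, with a stated time of 72 h (on this read-out lower numbers stand for stronger inhibition and higher numbers for weaker inhibition), compound 1 gives 24300 nM. In this assay compound 3 gives 13400 nM, so that a 1.8-fold lower number from compound 1 to compound 3 (0.26 log units; within the scatter). Compound 2 `O=C1COc2ccc(-c3cccc(NS(=O)(=O)c4ccc(F)cc4)c3)cc2N1C1CC1` has a different core from compound 1, and the difference between the two cores is not broken down here. In this assay compound 2 reaches only a limit, > 40000 nM. Compound 4 `COc1ccc(N2C(=O)COc3ccc(-c4cccc(NS(=O)(=O)c5ccc(F)cc5)c4)cc32)cc1` is related to compound 2 by the same change, (4-methoxyphenyl in place of cyclopropyl on an amide-type nitrogen in a ring), and has not yet been measured in this assay. Because compound 2 sits at the limit of > 40000 nM in this assay, at which 1 of the 3 values shown sits, and the same change elsewhere gave only a 1.8-fold lower number from compound 1 to compound 3 (0.26 log units; within the scatter), compound 4 is expected to remain near that limit, with an estimated step that the limit leaves unreadable from compound 2 to compound 4. The estimate for compound 4 in this assay is 45000 nM, expected between 20000 nM and 100000 nM.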

Compound 4, half-maximal inhibitory concentration: 28300 nM
Compound 4: middle estimate off by 1.6-fold (0.20 log units), on the high side; measured number inside the range.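

Compound 2 gives > 40000 nM in this assay, which is a limit of the assay and not a number. Replacing cyclopropyl with 4-methoxyphenyl on the amide-type nitrogen on this second core therefore gives only a bounded step, an at least 1.4-fold lower number from compound 2 to compound 4 (0.15 log units; that floor lies within the scatter). The two cores thus give no sign that the change carries differently from one to the other, but they do not show that it carries equally either: the same change on two cores in this assay, a 1.8-fold lower number (0.26 log units; within the scatter) from compound 1 to compound 3 and an at least 1.4-fold lower number (0.15 log units; that floor lies within the scatter) from compound 2 to compound 4; the limit leaves it open whether they differ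

The compounds shown leave open how a methyl group or a chain ending in an amine would behave on that nitrogen on either core. They also leave open the true size of the step on the second core.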